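A few compounds are considered here, and "the series" means these few. Any claim that something is new, unique, unknown or untested is made for them only; others in the source may bear on it.

Compound 1 `CC[C@@H]1O[C@H](COCc2ccccc2)[C@@H](OCc2ccccc2)[C@H](OCc2ccccc2)[C@H]1O`: 34200 nM in a functional assay on HOS cells (Homo sapiens) for antiproliferative activity, read by sulforhodamine B assay; a higher number here means a weaker inhibitor of growth, a lower number a stronger inhibitor of growth
Compound 2 `CC[C@H]1O[C@H](COCc2ccccc2)[C@@H](OCc2ccccc2)[C@H](OCc2ccccc2)[C@H]1O`: > 50000 nM, a limit in this assay
Compound 3 `CCC[C@@H]1O[C@H](COCc2ccc3ccccc3c2)[C@@H](OCc2ccc3ccccc3c2)[C@H](OCc2ccc3ccccc3c2)[C@H]1O`: > 50000 nM, a limit in this assay

Among the compounds with values here, compound 1 is the only compound with a number in this assay; the other two values are limits, as the limit of > 50000 nM in this assay, at which 2 of the 3 values shown sit, shows. Compound 4 `O[C@@H]1[C@@H](OCc2ccccc2)[C@H](OCc2ccccc2)[C@@H](COCc2ccccc2)O[C@H]1CC1CCCCC1` differs from compound 1 in one place: cyclohexyl in place of methyl on a saturated chain carbon bound to a saturated ring carbon. Within the data shown here, the only measured step, an at least 1.4-fold higher number from compound 1 to compound 2 (0.16 log units; that floor lies within the scatter), concerns a change in configuration alone, which is the fact that compounds 1 and 2 differ only in the configuration as drawn, and so says nothing about a change of substituent. Compound 3 yields only a limit. Among the measured compounds shown here, no measured step therefore bears on the change from compound 1 to compound 4, and no step beyond the scatter is expected. Compound 4 is estimated at 25000 nM in this assay, with a range from 7000 nM to 60000 nM, meaning an expected step of a 1.4-fold lower number from compound 1 to compound 4 (0.14 log units; within the scatter).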

Compound 4, concentration for 50% growth inhibition: 4400 nM
The estimate for compound 4 lay 5.7-fold (0.75 log units) above the measured number, outside the stated range (below it).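

In this assay, cyclohexyl in place of methyl on a saturated chain carbon bound to a saturated ring carbon gives a 7.8-fold lower number from compound 1 to compound 4 (0.89 log units; beyond the scatter). This is the only step shown that lies beyond the scatter, and it shows that the number responds to a change of substituent at this place, which the earlier compounds could not show. Nothing given accounts for this step. Going by these compounds, whether a longer straight chain or an amine at this place would lower the number as cyclohexyl does remains open. So does whether cyclohexyl would have the same effect with the opposite configuration at the ring carbon that separates compound 2 from compound 1.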